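Swapping the Ring on the Core: What Plasma Half-Life to Expect

A few compounds are considered here, and "the series" means these few. Any claim that something is new, unique, unknown or untested is made for them only; others in the source may bear on it.

Measured so far:
compound 1, `CN1CCC(c2ccc3c(c2)oc(=O)n3C(=O)NCCCCc2ccccc2)CC1=O`, 0.6 h
compound 2, `CC(C)CNC(=O)n1c(=O)oc2cc(C3CCCN(C)C3)ccc21`, 0.833 h
compound 3, `CN1CCC(c2ccc3c(c2)oc(=O)n3C(=O)NCCCCc2ccc(F)cc2)CC1`, 0.333 h

All three were tested in an ADME assay on a cell-free system (plasma, Mus musculus) for metabolic stability, read by LC-MS, tested at 2 uM; a higher number here means that the compound lasts longer, a lower number that the compound disappears faster. Compound 1 holds the second highest of the three half-lives, but its nearest neighbour, compound 2, lies within the usual scatter of it, and so does the furthest, compound 3. Nothing in these three numbers separates one compound from another with confidence.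

Compound 4, `CN1CCN(c2ccc3c(c2)oc(=O)n3C(=O)NCCCCc2ccccc2)CC1`, has not yet been measured. Compared with compound 1 it carries one change on an aromatic carbon of the shared core: 4-methylpiperazin-1-yl in place of 1-methyl-2-oxopiperidin-4-yl on an aromatic carbon. Among the compounds with values here, no pair of measured compounds differs in exactly this way, so the data give no direct measure of what such a swap does to half-life. What they do show is that three compounds with different groups on that aromatic carbon and different chains elsewhere all fall within the scatter of one another. On that basis the step expected in this assay is no change at the digits printed from compound 1 to compound 4 (within the scatter), which amounts to no shift beyond the scatter in either direction. Compound 4 is therefore estimated at 0.6 h, with a range from 0.25 h to 1.5 h.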

Compound 4, half-life: < 0.0834 h
Compound 4: a limit, no number; the forecaster's own chance of this, stated with the estimate: 5%; at least 7.1-fold (0.85 log units) between middle value and limit.
By their numbers in this assay, from the lowest: compounds 3, 1 and 2 (each within the scatter of the next, the first and the last beyond it). At a limit, below all of these: compound 4.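

Replacing 1-methyl-2-oxopiperidin-4-yl with 4-methylpiperazin-1-yl on an aromatic carbon of the shared core, with the rest of the molecule left as it is, gives an at least 7.1-fold lower number from compound 1 to compound 4 (0.85 log units; beyond the scatter) in this assay. The earlier compounds shown here differ from one another in more than one place, so they could not isolate a single group, whereas this pair shows that the group on this carbon can by itself move the half-life beyond the scatter. Compound 4 gives a limit and not a number, so the step marks only the smallest change that fits the data, and its full size remains unknown: the limit of < 0.0834 h in this assay, at which 1 of the 4 values shown sits.

The swap removes the ring carbonyl and brings in a second ring nitrogen at the same time, and this single pair cannot tell which of these differences matters, or whether both do. It also leaves open how a morpholin-4-yl group, which has a ring oxygen in place of the methyl-bearing nitrogen, would fare on this carbon, and whether 4-methylpiperazin-1-yl would give a similar step alongside the chain of compound 2.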